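A few compounds are considered here, and "the series" means these few. Any claim that something is new, unique, unknown or untested is made for them only; others in the source may bear on it.

Measured in an in vitro ADME assay on microsomes from liver (Homo sapiens) for pharmacokinetics, read by LC-MS; on this read-out lower numbers stand for slow clearance and higher numbers for fast clearance:
- compound 1 `Cc1nc2c(F)cccc2n1-c1ccc(C(=O)NC2CC2)s1`: < 4 mL/min/kg (a limit of the assay, not a number)
- compound 2 `Cc1cc(F)c2ncn(-c3ccc(C(=O)NC4CC4)s3)c2c1`: 10 mL/min/kg

Within the data shown here, in this small set, compound 2 gives the only actual number, 10 mL/min/kg. Compound 1 reports only a limit, so the two compounds cannot be ranked in any detail.

Compound 3 `O=C(NC1CC1)c1ccc(-n2cnc3c(F)cccc32)s1` is still unmeasured and differs from compound 2 at one place: hydrogen in place of methyl on an aromatic carbon. Put simply, hydrogen stands in place of methyl on an aromatic carbon.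

Among the measured compounds shown here, no two measured compounds differ at just one place, so nothing yet shows what such a change does in this assay. The expectation is therefore a cautious one: a step no larger than the usual scatter, leaning towards slower clearance. That lean rests only on compound 1, whose < 4 mL/min/kg is a limit. The expected change is a 1.7-fold lower number from compound 2 to compound 3 (0.22 log units; within the scatter), and it may prove indistinguishable from no change at all. The estimate for compound 3 is 6 mL/min/kg, with an expected range from 3 mL/min/kg to 13 mL/min/kg.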

Compound 3, clearance: 10 mL/min/kg
For compound 3 the middle estimate is 1.7-fold (0.22 log units) below the measured one; the measured number falls inside the stated range.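

In this assay, among these compounds, hydrogen in place of methyl on the aromatic carbon of the six-membered ring gives no change at the digits printed from compound 2 to compound 3 (within the scatter), so this is the first single-place step showing that the methyl at this place makes no readable difference to clearance. Compound 1 and compound 3 also differ in one place, a methyl on another aromatic carbon of the core, and there the same exchange gives an at least 2.5-fold higher number from compound 1 to compound 3 (0.39 log units; beyond the scatter), so the same swap reads differently depending on where the methyl sits. Compound 1 stands at a limit of the assay and not at a number, so the true size of that second step remains unknown: the limit of < 4 mL/min/kg in this assay, at which 1 of the 3 values shown sits.

With a single pair for each place, neither reading can yet be called a pattern, and the data give no reason for the difference between the two places. As far as these compounds go, it also remains open whether something larger than methyl on the six-membered ring, such as a methoxy group or a chlorine atom, would leave clearance just as unchanged as hydrogen does in this assay.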